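Swapping the Methoxyphenyl Group for a Pyridine Ring

The source may report more compounds than this note shows. Statements on the series, on what has been measured and on what is new or still open speak of the compounds shown alone.

Of the compounds shown here, three sharing one core have been measured in a functional assay on KB-VIN10 cells (Homo sapiens) for inhibition, with a stated time of 72 h; a higher number here means a weaker inhibitor, a lower number a stronger inhibitor. Compound 1 `COc1ccc(S(=O)(=O)N2CCc3cccc(-c4cccnc4)c32)cc1` carries a pyridin-3-yl group and gives 84.5 nM. Compound 2 `COc1ccc(S(=O)(=O)N2CCc3cccc(-c4ccc(F)nc4)c32)cc1` carries a 6-fluoropyridin-3-yl group and gives 151 nM; the step of a 1.8-fold higher number from compound 1 to compound 2 (0.25 log units; within the scatter) stays within the usual scatter. Compound 3 `COc1ccc(-c2cccc3c2N(S(=O)(=O)c2ccc(OC)cc2)CC3)cc1` carries a 4-methoxyphenyl group and gives 352 nM, the highest of the three numbers and so the weakest inhibitor of the set, since the step of a 4.2-fold higher number from compound 1 to compound 3 (0.62 log units; beyond the scatter) and the step of a 2.3-fold higher number from compound 2 to compound 3 (0.37 log units; beyond the scatter) are both beyond the scatter.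

Compound 4 `COc1ccc(S(=O)(=O)N2CCc3cccc(-c4ccncc4)c32)cc1` is the next compound. It differs from compound 3 in one place: pyridin-4-yl in place of 4-methoxyphenyl on an aromatic carbon. The closest guide is the step from compound 1 to compound 3, in which a pyridin-3-yl group gave way to the 4-methoxyphenyl group and the number rose. For the measured compounds named here, the change to compound 4 puts a pyridine ring back, though a different pyridinyl group, and no measured pair shows how pyridin-4-yl compares with pyridin-3-yl. The expectation is therefore a step down in this assay, roughly reversing a 4.2-fold higher number from compound 1 to compound 3 (0.62 log units; beyond the scatter), with added uncertainty. Compound 4 is expected to give 100 nM, within a range from 40 nM to 250 nM. The estimated step of a 3.5-fold lower number from compound 3 to compound 4 (0.55 log units; beyond the scatter) is expected to lie beyond the scatter.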

Compound 4, half-maximal inhibitory concentration: 106 nM
Compound 4: the middle estimate sits 1.1-fold (0.03 log units) below what was measured; measured number inside the range.
By their numbers in this assay, from the lowest: compounds 1, 4 and 2 (each within the scatter of the next); then compound 3.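

For the compounds shown here, putting a pyridine ring back in place of the 4-methoxyphenyl group, this time as pyridin-4-yl, brings (a 3.3-fold lower number from compound 3 to compound 4 (0.52 log units; beyond the scatter)), so the gain is no longer tied to the single pyridin-3-yl group of compound 1. Among the rings on this aromatic carbon, pyridin-4-yl cannot be told apart from pyridin-3-yl (a 1.3-fold higher number from compound 1 to compound 4 (0.10 log units; within the scatter)) or from 6-fluoropyridin-3-yl (a 1.4-fold lower number from compound 2 to compound 4 (0.15 log units; within the scatter)), which means that in (this assay) all three pyridine compounds sit together, each with a lower number than compound 3 by a step beyond the scatter. Nothing measured here bears on why the pyridine rings differ from the 4-methoxyphenyl ring.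

Every compound shown carries a six-membered aromatic ring at this carbon, so it remains open whether a saturated amine such as morpholine or piperidine, or a carboxylic acid, would keep the number at the level of compound 1. Also open, as far as these compounds go, is whether a methoxy group on a pyridine ring, or a fluoro group on the pyridin-4-yl ring of compound 4, would move the number beyond the scatter.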